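Lengthening the Acetamide Chain of a Kinase Inhibitor

The source may report more compounds than this note shows. Statements on the series, on what has been measured and on what is new or still open speak of the compounds shown alone.

The measurements come from an assay on isolated protein for inhibition of Rho-associated protein kinase 2 (Homo sapiens), read by scintillation counting, radiometric assay and 33P incorporation, with a stated time of 40 min, in the presence of a further agent that is not named here; a higher number here means a weaker inhibitor, a lower number a stronger inhibitor. Compound 1 `COc1ccc(OCC(=O)Nc2cccc(NC(=O)c3ccc(N(C)C)cc3)c2)cc1OC` carries two methoxy groups on its outer ring; in this assay compound 1 reaches only the assay limit of > 10000 nM, so no number is known for it. Compound 2 `COc1ccc(OCC(=O)Nc2cccc(NC(=O)c3ccc(N(C)C)cc3)c2)cc1F` replaces one of these methoxy groups with fluorine, and in this assay compound 2 gives 652 nM. That single change produced an at least 15-fold lower number from compound 1 to compound 2 (1.18 log units; beyond the scatter), where the starting point rests on (the limit of > 10000 nM in this assay, at which 1 of the 3 values shown sits).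

Compound 3 `CC(=O)Nc1cccc(NC(=O)COc2ccc3c(=O)ccoc3c2)c1` has a different shape: an acetamido group on one side of the central ring and a chromone-bearing ether on the other. In this assay compound 3 gives 136 nM, the lowest of the two numbers, with the nearest number, that of compound 2, higher by a margin beyond the usual scatter.

Compound 4 `CCCC(=O)Nc1cccc(NC(=O)COc2ccc3c(=O)ccoc3c2)c1` differs from compound 3 by ethyl in place of hydrogen on a saturated chain carbon bound to a carbonyl carbon. Among the compounds with values here, none of the measured steps touches this kind of change: the only measured step concerns a fluorine for a methoxy group on an aromatic ring, not a longer chain on the amide. With nothing to point either way, a shift beyond the scatter is not expected, and the estimate for compound 4 is 140 nM, between 45 nM and 450 nM, corresponding to an expected 1.0-fold higher number from compound 3 to compound 4 (0.01 log units; within the scatter).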

Compound 4, half-maximal inhibitory concentration: 176 nM
Estimate against measurement, compound 4: 1.3-fold (0.10 log units) below; low and high end bracket the measured number.
By their numbers in this assay, from the lowest: compounds 3 and 4 (each within the scatter of the next); then compound 2. At a limit, above all of these: compound 1.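

Replacing the acetamido group with (propylcarbonyl)amino gives a 1.3-fold higher number from compound 3 to compound 4 (0.11 log units; within the scatter) in this assay, so the two compounds cannot be told apart in this measurement. Within the data shown here, this is the first reading at this end of the molecule, as the only earlier step between compounds differing in one place concerned fluoro in place of methoxy on an aromatic carbon, and it shows that this chain can carry ethyl in place of hydrogen without a shift beyond the usual scatter on the core of compound 3. The data shown give no reason why the added ethyl leaves the number within the scatter.

As far as these compounds go, the pair covers one short, unbranched addition on one core, so it remains open how far this tolerance extends: a longer chain, a branched chain such as isopropyl, or a chain ending in an amine or a carboxylic acid could behave quite differently at the same place. From the compounds shown here alone, it also remains open whether the same ethyl addition would leave the number within the scatter on a core other than that of compound 3.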